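Nitro for methyl on the sulfonamide arm of a coumarin

The source may hold more compounds than are shown below. What is called first, only, known or untested is meant among the compounds shown, and "the series" means these compounds.

Measured compounds:
compound 1 `O=c1cc(Cn2cc(CCCCl)nn2)c2ccc(O)cc2o1` gives 59800 nM in a functional assay on SW-620 cells (Homo sapiens) for inhibition, read by MTT assay, with a stated time of 72 h; on this read-out lower numbers stand for stronger inhibition and higher numbers for weaker inhibition
compound 2 `Cc1ccc(S(=O)(=O)NCc2cn(Cc3cc(=O)oc4cc(O)ccc34)nn2)cc1` gives 92200 nM in this assay

Both compounds show weak inhibition on this read-out. Compound 2 has the highest of the two numbers, but its nearest neighbour, compound 1, sits only slightly lower, and that gap lies within the scatter of repeated measurements; the two values therefore cannot be ordered against each other.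

Compound 3 `O=c1cc(Cn2cc(CNS(=O)(=O)c3ccc([N+](=O)[O-])cc3)nn2)c2ccc(O)cc2o1` is not yet measured. It differs from compound 2 in one place: nitro in place of methyl on an aromatic carbon. Going by the values given here, no pair of measured compounds shows this kind of change, so there is no step on which to base the size or direction of its effect. The two measured values together only mark out a weak range for this core, and nothing suggests that the exchange of one small group for another on the outer aromatic ring would move the number beyond the scatter. The step from compound 2 to compound 3 is expected to be a 1.1-fold lower number from compound 2 to compound 3 (0.04 log units; within the scatter), in no clear direction. For compound 3 in this assay the estimate is 85000 nM, with a range from 30000 nM to 250000 nM.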

Compound 3, half-maximal inhibitory concentration: > 100000 nM
Compound 3: no number, only a limit; the forecaster's own chance of this, stated with the estimate: 30%; middle value at least 1.1-fold (0.07 log units) from the limit.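

In this assay compound 3 gives > 100000 nM, which is a limit of the assay and not a number. Going by these compounds alone, this is the first reading of a change on the outer aromatic ring, and going from 4-methylphenyl to 4-nitrophenyl gives an at least 1.0-fold higher number from compound 2 to compound 3 (0.03 log units; that floor lies within the scatter), so the position shows no sign of stronger inhibition with nitro, while the size of the step stays open because only its floor is known, and that floor lies within the scatter. The whole reading for this change rests on a single capped result: the limit of > 100000 nM in this assay, at which 1 of the 3 values shown sits.

The compounds shown leave open whether the true value of compound 3 would sit within the scatter of compound 2 or well beyond it, and a single exchange on this ring gives no trend for the position. Nor do they tell whether an amine, a carboxylic acid or a longer chain at this spot on the ring, para to the large group, would move the number out of the weak range seen so far for the shared core.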